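A few compounds are considered here, and "the series" means these few. Any claim that something is new, unique, unknown or untested is made for them only; others in the source may bear on it.

Compound 3 `CCCCc1ccc(CNS(=O)(=O)c2ccc(C)cc2)c(=O)n1Cc1ccc(-c2ccccc2-c2nn[nH]n2)cc1` stands at the weak end of the three measured compounds: in a functional assay (aorta) for antagonist activity, with Oryctolagus cuniculus as the target (a lower number here means a stronger inhibitor, a higher number a weaker inhibitor), compound 3 gives 9 nM, while compound 1 `CCCCc1cccc(=O)n1Cc1ccc(-c2ccccc2-c2nn[nH]n2)cc1` gives 4 nM and compound 2 `CCCCc1ccc(CN(C)S(C)(=O)=O)c(=O)n1Cc1ccc(-c2ccccc2-c2nn[nH]n2)cc1` gives 0.2 nM. The steps read a 2.3-fold higher number from compound 1 to compound 3 (0.35 log units; beyond the scatter) and, far larger, a 45-fold higher number from compound 2 to compound 3 (1.65 log units; beyond the scatter); the step of a 20-fold lower number from compound 1 to compound 2 (1.30 log units; beyond the scatter) shows how much the methyl(methylsulfonyl)amino group gains over hydrogen on that aromatic carbon.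

Compound 4 `CCCCc1ccc(CN(C(C)C)S(C)(=O)=O)c(=O)n1Cc1ccc(-c2ccccc2-c2nn[nH]n2)cc1` differs from compound 3 in one place: isopropyl(methylsulfonyl)amino in place of ((4-methylphenyl)sulfonyl)amino on a saturated chain carbon bound to an aromatic carbon. Within the data shown here, this change undoes most of what separated compound 2 from compound 3, keeping the methylsulfonyl group and adding an isopropyl group on the nitrogen in place of methyl, a swap no measured pair tests directly. Because of a 45-fold higher number from compound 2 to compound 3 (1.65 log units; beyond the scatter), a large step toward lower numbers is expected, though not necessarily all the way to compound 2. In this assay compound 4 is therefore estimated at 0.5 nM, with a range from 0.1 nM to 3 nM. The expected step is an 18-fold lower number from compound 3 to compound 4 (1.26 log units; beyond the scatter).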

Compound 4, half-maximal inhibitory concentration: 0.9 nM
For compound 4 the middle estimate is 1.8-fold (0.26 log units) below the measured one; low and high end bracket the measured number.
By their numbers in this assay, from the lowest: compound 2; then compound 4; then compound 1; then compound 3.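

In this assay the sulfonamide nitrogen proves sensitive to the size of its alkyl group, with isopropyl in place of methyl giving a 4.5-fold higher number from compound 2 to compound 4 (0.65 log units; beyond the scatter). Even so, the isopropyl compound keeps a gain over hydrogen on the aromatic carbon, with a 4.4-fold lower number from compound 1 to compound 4 (0.65 log units; beyond the scatter), so two of the three substituents at this place give lower numbers than hydrogen, and compound 3 goes against that pattern. The step of a 10-fold lower number from compound 3 to compound 4 (1.00 log units; beyond the scatter) combines two differences, the loss of the 4-methylphenyl group on sulfur and the alkylation of the nitrogen, and the compounds cannot separate them. No evidence at hand accounts for these differences.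

As far as these compounds go, it remains open whether an ethyl group on the nitrogen would give a number between those of compound 2 and compound 4. Also open, from the compounds shown here alone, is how a 4-methylphenylsulfonyl group would fare on a nitrogen carrying methyl.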